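This account rests on a few compounds, and the source may have more. Where it says the series, first, only, none or still open, it means among the compounds named here.

Measured compounds:
compound 1, `O=C(Nc1cccc(O)c1)c1nccc2ccccc12`: > 10000 nM
compound 2, `O=C(Nc1cc(C(F)(F)F)cc(C(F)(F)F)c1)c1nccc2ccccc12`: > 10000 nM

In a functional assay on NUGC-3 cells (Homo sapiens) for inhibition, read by sulforhodamine B assay, with a stated time of 48 h (on this read-out higher numbers stand for weaker inhibition of growth and lower numbers for stronger inhibition of growth), compound 1 gives > 10000 nM, which is a limit of the assay and not a number. In this assay compound 2 gives > 10000 nM, again a limit of the assay. Compound 2 thus stands at the limit of > 10000 nM in this assay, at which 2 of the 2 values shown sit; no number exists for it, and nothing on the values shown separates it from compound 1.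

Compound 3, `O=C(Nc1cccc(C(F)(F)F)c1)c1nccc2ccccc12`, is to be measured in this assay. It differs from compound 2 in one place: hydrogen in place of trifluoromethyl on an aromatic carbon. Among the measured compounds shown here, no step between measured compounds is available to size this change, and both values shown are limits. The step expected from this change is a step that the limit leaves unreadable from compound 2 to compound 3, with no direction assumed and a further limit the most likely outcome. For compound 3 the estimate in this assay is 15000 nM, within 3000 nM to 80000 nM.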

Compound 3, concentration for 50% growth inhibition: > 10000 nM
Compound 3 was reported as a limit (the forecaster's own chance of this, stated with the estimate: 70%); the middle value lies beyond the limit too.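

No new step can be read among compound 1, compound 2 and compound 3, which all give only a limit of the assay in this assay: the limit of > 10000 nM in this assay, at which 3 of the 3 values shown sit.

The compounds shown leave open how these three compare and whether any change to the groups on the shared core alters growth inhibition.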